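Benzothiazolyl thioureas: acyl variation and cytotoxicity on cells

A few compounds are considered here, and "the series" means these few. Any claim that something is new, unique, unknown or untested is made for them only; others in the source may bear on it.

Measured so far in a functional assay on HeLa cells (Homo sapiens) for cytotoxicity, read by MTT assay, with a stated time of 24 h; on this read-out higher numbers stand for weaker inhibition and lower numbers for stronger inhibition:
compound 1 `O=C(NC(=S)Nc1nc2cc(Br)ccc2s1)c1ccccc1`: 64600 nM
compound 2 `O=C(NC(=S)Nc1nc2cc(Br)ccc2s1)c1ccc([N+](=O)[O-])cc1`: 56500 nM

Compound 1 stands highest of the two numbers in this assay; its nearest neighbour is compound 2, and the step of a 1.1-fold lower number from compound 1 to compound 2 (0.06 log units; within the scatter) is within the scatter. Compound 3 `O=C(NC(=S)Nc1nc2cc(Br)ccc2s1)N1CCOCC1` differs from compound 1 by morpholin-4-yl in place of phenyl on a carbonyl carbon. Among the compounds with values here, no measured step touches the acyl side of the thiourea; the single step known, from compound 1 to compound 2, concerns a ring substituent and was within the scatter. Nothing therefore supports a shift beyond the scatter, and compound 3 is expected to show a 1.0-fold higher number from compound 1 to compound 3 (0.00 log units; within the scatter). In this assay compound 3 is estimated at 65000 nM, with a range from 30000 nM to 150000 nM.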

Compound 3, half-maximal inhibitory concentration: 38900 nM
The estimate for compound 3 lay 1.7-fold (0.22 log units) above the measured number; the range from low to high includes it.
By their numbers in this assay, from the lowest: compounds 3, 2 and 1 (each within the scatter of the next).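

With morpholin-4-yl in place of phenyl on the carbonyl carbon, this assay gives a 1.7-fold lower number from compound 1 to compound 3 (0.22 log units; within the scatter) for an exchange of the whole group, whereas the earlier step altered only a substituent on the phenyl. An aromatic ring of carbon at this place is therefore not required for a number in this range, and a non-aromatic ring with 2 hetero atoms is tolerated. No available measurement explains this result.

Going by these compounds, whether the ring oxygen matters remains open, and piperidin-1-yl would address that. On these data alone, whether a ring is needed at all remains open too, and an open-chain amine such as diethylamino would address that.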